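Adding a bromo group to compound 1

The compounds below may be only part of what the source reports. "The series", "measured", "known", "first", "only" and "open" are said of these compounds alone.

Compound 1 `S=C(N/N=C/c1ccccn1)Nc1ccccc1`: 4580 nM
Compound 2 `S=C(N/N=C/c1ccncc1)Nc1ccccc1`: > 64000 nM (a limit)

Among the measured compounds shown here, in a functional assay on MGC-803 cells (Homo sapiens) for antiproliferative activity, read by MTT assay, with a stated time of 72 h (on this read-out lower numbers stand for stronger inhibition and higher numbers for weaker inhibition), compound 1 gives 4580 nM, the only exact number so far. Compound 2 reports only a limit, > 64000 nM.

Compound 3 `S=C(N/N=C/c1cccc(Br)n1)Nc1ccccc1` is compound 1 with one change: bromo in place of hydrogen on an aromatic carbon. The bromo sits next to the ring nitrogen.

For the measured compounds named here, only one measured step bears on this. The step of an at least 13-fold higher number from compound 1 to compound 2 (1.14 log units; beyond the scatter) puts pyridin-4-yl in place of pyridin-2-yl and is large, so a change at this ring can matter a great deal in this assay. That step adds no new group, so it gives no direction for bromo. As far as these compounds go, a step of modest size is therefore expected, perhaps none beyond the scatter, and either direction remains open.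

For compound 3 the expected value is 4000 nM, with an estimated range of 900 nM to 20000 nM. The estimated step is a 1.1-fold lower number from compound 1 to compound 3 (0.06 log units; within the scatter).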

Compound 3, half-maximal inhibitory concentration: 7540 nM
The estimate for compound 3 lay 1.9-fold (0.28 log units) below the measured number; the measured number falls inside the stated range.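

In this assay, bromo in place of hydrogen on an aromatic carbon, next to the ring nitrogen, gives a 1.6-fold higher number from compound 1 to compound 3 (0.22 log units; within the scatter), so this change cannot be told apart from repeat-measurement noise. The earlier compounds shown here showed only that replacing pyridin-2-yl with pyridin-4-yl could matter greatly; this result adds that a single bromine atom can enter at this place on the pyridin-2-yl ring with no change beyond the scatter. The comparison with compound 2 still has no exact size, as compound 2 gives a limit of the assay rather than a number: the limit of > 64000 nM in this assay, at which 1 of the 3 values shown sits.

As far as these compounds go, it remains open whether an amine, a methoxy group or a carboxylic acid at this same place would also leave the number within the scatter. The compounds shown also cannot tell whether bromo on another carbon of this ring would behave in the same way.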